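Replacing the quinolin-2-yl group of compound 3

This account rests on a few compounds, and the source may have more. Where it says the series, first, only, none or still open, it means among the compounds named here.

compound 1 `Oc1ccc(OCc2ccc3ccccc3n2)cc1C1(c2ccccc2)CCCC1` gives 1920 nM
compound 2 `COC(=O)COc1ccc(OCc2ccc3ccccc3n2)cc1C1(c2ccccc2)CCCC1` gives 890 nM
compound 3 `c1ccc(C2(c3cc(OCc4ccc5ccccc5n4)ccc3OCc3ccc4ccccc4n3)CCCC2)cc1` gives 1080 nM

All three numbers come from a functional assay on blood (Homo sapiens) for inhibition (on this read-out higher numbers stand for weaker inhibition and lower numbers for stronger inhibition), and compound 3 cannot be told apart from either of the other two (a 1.8-fold lower number from compound 1 to compound 3 (0.25 log units; within the scatter); a 1.2-fold higher number from compound 2 to compound 3 (0.08 log units; within the scatter)). Among the compounds with values here, only one step in the set lies beyond the scatter, and it is modest (a 2.2-fold lower number from compound 1 to compound 2 (0.33 log units; beyond the scatter)).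

Compound 4 `C1=CC(COc2ccc(OCc3ccc4ccccc4n3)cc2C2(c3ccccc3)CCCC2)=CNC1` keeps the shared core and changes in one place, on a saturated chain carbon bound to an oxygen on an aromatic ring (a group of 6 heavy atoms (5 carbon, 1 nitrogen; one six-membered non-aromatic ring with 1 hetero atom) in place of a group of 10 heavy atoms (9 carbon, 1 nitrogen; one six-membered aromatic ring of carbon only, one six-membered aromatic ring with 1 hetero atom), on a saturated chain carbon bound to an oxygen on an aromatic ring). The measured steps all concern groups on that same oxygen, and even the replacement of methoxycarbonyl by quinolin-2-yl changed little (a 1.2-fold higher number from compound 2 to compound 3 (0.08 log units; within the scatter)). Within the data shown here, no measured compound carries the entering ring, so this comparison is only a rough guide. No step beyond the scatter is therefore expected in this assay, and the expected step is small (a 1.1-fold higher number from compound 3 to compound 4 (0.05 log units; within the scatter)). Compound 4 is estimated at 1200 nM (expected range 500 nM to 2800 nM).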

Compound 4, half-maximal inhibitory concentration: 200 nM
Compound 4: the middle estimate sits 6.0-fold (0.78 log units) above what was measured, outside the stated range (below it).
By their numbers in this assay, from the lowest: compound 4; then compounds 2, 3 and 1 (each within the scatter of the next, the first and the last beyond it).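

In this assay the group on this saturated chain carbon can matter after all: methoxycarbonyl and quinolin-2-yl could not be told apart, yet the entering non-aromatic ring stands clear of both (a 5.4-fold lower number from compound 3 to compound 4 (0.73 log units; beyond the scatter); a 4.5-fold lower number from compound 2 to compound 4 (0.65 log units; beyond the scatter)), and also of hydrogen on the oxygen (a 9.6-fold lower number from compound 1 to compound 4 (0.98 log units; beyond the scatter)). Group size does not order these compounds, as the entering ring lies between methoxycarbonyl and quinolin-2-yl in heavy atoms yet gives the lowest number of the set. Nothing measured here explains this gain.

As far as these compounds go, it remains open whether a saturated piperidine ring or an aromatic pyridine ring on the same carbon would keep the lower number. Also open, from the compounds shown here alone, is whether the ring's hydrogen-bond donor or its two double bonds play any part, which a cyclohexyl ring would begin to test.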